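Swapping Bromo for Chloro and Trifluoromethyl on the Anilide

A few compounds are considered here, and "the series" means these few. Any claim that something is new, unique, unknown or untested is made for them only; others in the source may bear on it.

Of the compounds shown here, three sharing one core have been measured in a functional assay on OVCAR-5 cells (Homo sapiens) for inhibition, read by CCK-8 assay, with a stated time of 72 h, tested at 1 uM; a lower number here means less inhibition of growth, a higher number more inhibition of growth at the concentration tested. Compound 1 `CN(C)C(=O)c1cc2cnc(Nc3ccc(NC(=O)C4(C(=O)Nc5ccccc5)CC4)cc3)nc2n1C1CCCC1` carries an unsubstituted phenyl on an amide-type nitrogen and gives 52.1%. Compound 2 `CN(C)C(=O)c1cc2cnc(Nc3ccc(NC(=O)C4(C(=O)Nc5ccccc5F)CC4)cc3)nc2n1C1CCCC1` gives 58%, and a number 5.9 percentage points higher from compound 1 to compound 2 (within the scatter). Compound 3 `CN(C)C(=O)c1cc2cnc(Nc3ccc(NC(=O)C4(C(=O)Nc5ccc(Br)cc5)CC4)cc3)nc2n1C1CCCC1` gives 13.7%, the lowest of the three: a number 38.4 percentage points lower from compound 1 to compound 3 (beyond the scatter), and a number 44.3 percentage points lower from compound 2 to compound 3 (beyond the scatter).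

Compound 4 `CN(C)C(=O)c1cc2cnc(Nc3ccc(NC(=O)C4(C(=O)Nc5ccc(Cl)c(C(F)(F)F)c5)CC4)cc3)nc2n1C1CCCC1` has not yet been tested. It differs from compound 3 at one place: 4-chloro-3-(trifluoromethyl)phenyl in place of 4-bromophenyl on an amide-type nitrogen. Both measured steps that touch this part of the molecule point the same way: the bromophenyl of compound 3 went together with far less growth inhibition than the phenyl of compound 1 or the fluorophenyl of compound 2. Among the compounds with values here, no measured pair shows what a trifluoromethyl on this ring does, so that part of the change is untested. Because a number 38.4 percentage points lower from compound 1 to compound 3 (beyond the scatter) was large and the chloro keeps a halogen on the phenyl, compound 4 is expected to remain near the low end. The step of a number 4.3 percentage points higher from compound 3 to compound 4 (within the scatter) is expected to stay within the scatter. The estimated value for compound 4 is 18%, with a range from 0% to 45%.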

Compound 4, percent growth inhibition at one concentration: -2.4%
Compound 4: middle estimate off by 20.4 percentage points, on the high side; measured number outside the range, below it.
By their numbers in this assay, from the lowest: compound 4; then compound 3; then compounds 1 and 2 (each within the scatter of the next).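

In this assay, the fall seen with the 4-bromophenyl was not the lowest this position can reach: a number 16.1 percentage points lower from compound 3 to compound 4 (beyond the scatter), so replacing it with 4-chloro-3-(trifluoromethyl)phenyl on the amide-type nitrogen takes growth inhibition further down. The loss against the two more active compounds is much greater, a number 54.5 percentage points lower from compound 1 to compound 4 (beyond the scatter) and a number 60.4 percentage points lower from compound 2 to compound 4 (beyond the scatter), and this widens the gap already opened by the 4-bromophenyl, so across these four compounds the two rings carrying a halogen at the 4 position of the phenyl are the two with low numbers, while the 2-fluorophenyl of compound 2 goes against any reading that a halogen on this ring is enough to lower the number. No outside measurement is available here that would explain these differences.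

Chloro and trifluoromethyl enter together in compound 4, so their separate shares in the step remain open, and a 4-chlorophenyl or a 3-(trifluoromethyl)phenyl on the same nitrogen would pull them apart. Also open, as far as these compounds go, is whether a ring carrying an amine or a carboxylic acid at this place would bring the number back up towards that of compound 1.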